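Swapping the aminophenyl arm for a pyridyl ring

The source may report more compounds than this note shows. Statements on the series, on what has been measured and on what is new or still open speak of the compounds shown alone.

Measured so far:
- compound 1, `Nc1cccc(-c2cn(CC(=O)Nc3nccs3)nn2)c1`: 1270 nM
- compound 2, `COC(=O)c1ccc(-c2cn(CC(=O)Nc3nc(C)cs3)nn2)cc1`: > 30000 nM
- compound 3, `Cc1csc(NC(=O)Cn2cc(-c3cccc(N)c3)nn2)n1`: 250 nM

All three share a core and were tested in a functional assay on BMDM cells (Mus musculus, strain C57BL/6) for inhibition, with a stated time of 2 days; on this read-out lower numbers stand for stronger inhibition and higher numbers for weaker inhibition. Compound 3 stands lowest of the two numbers shown. Among the measured compounds shown here, its nearest neighbour is compound 1, and the single measured step, a 5.1-fold lower number from compound 1 to compound 3 (0.71 log units; beyond the scatter), lies beyond the scatter. For compound 2 the assay reports only a limit, (the limit of > 30000 nM in this assay, at which 1 of the 3 values shown sits), and not a number.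

Compound 4, `Cc1csc(NC(=O)Cn2cc(-c3ccncc3)nn2)n1`, is not yet measured. It differs from compound 3 in one place: pyridin-4-yl in place of 3-aminophenyl on an aromatic carbon. For the measured compounds named here, no measured step touches this position; the one step recorded concerns the methyl on the thiazole, which compound 4 keeps. Going by the values given here, the only other compound with a different group at this place, compound 2, sits at the limit, so the evidence there is thin. Among the compounds with values here, with no step to lean on, the expectation for compound 4 is a weaker inhibition than compound 3, a step of about an 8.0-fold higher number from compound 3 to compound 4 (0.90 log units; beyond the scatter), with wide uncertainty. Compound 4 is thus estimated at 2000 nM, between 400 nM and 10000 nM.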

Compound 4, half-maximal inhibitory concentration: 100 nM
The estimate for compound 4 lay 20-fold (1.30 log units) above the measured number, and the stated range ends above it.
By their numbers in this assay, from the lowest: compound 4; then compound 3; then compound 1. At a limit, above all of these: compound 2.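

In this assay, replacing the 3-aminophenyl group with pyridin-4-yl gave a 2.5-fold lower number from compound 3 to compound 4 (0.40 log units; beyond the scatter). This is the first measured step at this position, and it shows that inhibition here does not need the amine or its hydrogen-bond donor, since pyridin-4-yl has no such donor and still gives the lowest number shown. A change of ring at this position therefore does not always cost activity, although compound 2, carrying a methyl ester on its phenyl ring, gives only a limit and not a number: the limit of > 30000 nM in this assay, at which 1 of the 4 values shown sits.

A plain phenyl ring, with neither the amine nor the ring nitrogen, would help show whether the nitrogen of pyridin-4-yl contributes to this gain. On these data alone, it also remains open how a carboxylic acid or a methoxy group on the ring would fare at this position.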